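The source may hold more compounds than are shown below. What is called first, only, known or untested is meant among the compounds shown, and "the series" means these compounds.

In a functional assay on NCI-H460 cells (Homo sapiens) for antiproliferative activity, read by MTT assay, with a stated time of 48 h (a lower number here means a stronger inhibitor, a higher number a weaker inhibitor), compound 1 `Cc1ccc(Nc2ccc3c(c2)C(O)(CCC(C)C)C(=O)N3)cc1` gives 22700 nM and compound 3 `Cc1ccc(Nc2ccc3c(c2)C(O)(Cc2ccccc2)C(=O)N3)cc1` gives 31600 nM. These two values lie within the scatter of each other. Compound 2 `CCCCCCC1(O)C(=O)Nc2ccc(Nc3ccc(C)cc3)cc21` reaches only a limit of this assay, > 100000 nM. Compound 4 `O=C1Nc2ccc(Nc3ccc(F)cc3)cc2C1(O)Cc1ccccc1` departs from compound 3 at one place: fluoro in place of methyl on an aromatic carbon, para to a large group. The measured steps all alter the chain on the shared core and leave this aromatic group untouched. Two of them rest on the limit, an at least 4.4-fold higher number from compound 1 to compound 2 (0.64 log units; beyond the scatter) and an at least 3.1-fold lower number from compound 2 to compound 3 (0.50 log units; beyond the scatter), while a 1.4-fold higher number from compound 1 to compound 3 (0.14 log units; within the scatter) stays within the scatter. None tests this exchange, so no shift beyond the scatter is expected in this assay. Compound 4 is estimated at 30000 nM, with an expected range of 12000 nM to 75000 nM. The expected change is a 1.1-fold lower number from compound 3 to compound 4 (0.02 log units; within the scatter).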

Compound 4, half-maximal inhibitory concentration: 18100 nM
For compound 4 the middle estimate is 1.7-fold (0.22 log units) above the measured one; the range from low to high includes it.
By their numbers in this assay, from the lowest: compounds 4, 1 and 3 (each within the scatter of the next). At a limit, above all of these: compound 2.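

In this assay, the exchange of 4-methylphenyl for 4-fluorophenyl is the only one shown on this aromatic ring rather than on the chain, and it gives a 1.7-fold lower number from compound 3 to compound 4 (0.24 log units; within the scatter). At this place, para to a large group, fluoro in place of methyl therefore brings no shift beyond the scatter. Nothing shown bears on a cause for this. On these data alone, whether an amine, a methoxy or a trifluoromethyl at this place would move the number stays open. So does whether the same exchange would read alike on the chain of compound 1.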